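Allyl series: a third methoxy on the aryl ring

The source may report more compounds than this note shows. Statements on the series, on what has been measured and on what is new or still open speak of the compounds shown alone.

Going by the values given here, compound 2 `C=CCn1c(SCC(=O)Nc2ccc(/C(C)=N/O)cc2)nnc1-c1ccc(OC)c(OC)c1` and compound 1 `CCn1c(SCC(=O)Nc2ccc(/C(C)=N/O)cc2)nnc1-c1cc(OC)c(OC)c(OC)c1` are the two measured members. In a functional assay on the whole organism (strain albino) for inhibition, with Rattus norvegicus as the target, read by paw edema, with stated times of 30 min and 2 h, at a dose of 0.28 mmol/kg by the oral route (a higher number here means more inhibition at the dose given (going by the name of the read-out), a lower number less inhibition), compound 2 gives 56%; compound 1 gives 49%, and the two numbers sit within the usual scatter of each other, so neither stands apart. Compound 3 `C=CCn1c(SCC(=O)Nc2ccc(/C(C)=N/O)cc2)nnc1-c1cc(OC)c(OC)c(OC)c1` is not yet measured; it differs from compound 2 by methoxy in place of hydrogen on an aromatic carbon. Compound 1 already carries three methoxy groups and gives 49%, so only a step inside the scatter is expected, a number 4 percentage points lower from compound 2 to compound 3 (within the scatter). Compound 3 is expected to give 52%, within 40% to 64%.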

Compound 3, a percentage reported as inhibition, in the whole organism at one dose (the size of the read-out at that dose, not a potency): 53%
Compound 3: middle estimate off by 1 percentage points, on the low side; measured number inside the range.
By their numbers in this assay, from the lowest: compounds 1, 3 and 2 (each within the scatter of the next).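

In this assay methoxy in place of hydrogen on this aromatic carbon gives a number 3 percentage points lower from compound 2 to compound 3 (within the scatter) and so the third methoxy, ortho to a methoxy group, leaves no step beyond the scatter. Compound 3 also opens a one-place comparison at the chain on the aromatic nitrogen: vinyl in place of methyl gives a number 4 percentage points higher from compound 1 to compound 3 (within the scatter) and so this change is not resolved at the single dose. No data on the cause of either step are available.

Open, from the compounds shown here alone, is whether a hydroxyl or chlorine at this aromatic carbon, or a longer chain such as butyl on the aromatic nitrogen, would give a step beyond the scatter. Potency also stays open, since the read-out reflects one dose only.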